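Phenoxy in place of benzyloxycarbonyl: working notes on the series

The compounds below may be only part of what the source reports. "The series", "measured", "known", "first", "only" and "open" are said of these compounds alone.

Of the compounds shown here, two with a shared core have been read so far. In a functional assay on A549 cells (Homo sapiens) for inhibition, read by CellTiter-Glo, with a stated time of 48 h, in the presence of a further agent that is not named here (on this read-out lower numbers stand for stronger inhibition of growth and higher numbers for weaker inhibition of growth), compound 1 `C#CCCCC(=O)Nc1ccc(C(=O)c2ccc(Nc3ncc(F)c(Nc4ccccc4NS(C)(=O)=O)n3)cc2)cc1` gives 15500 nM. Compound 2 `CS(=O)(=O)Nc1ccccc1Nc1nc(Nc2ccc(C(=O)OCc3ccccc3)cc2)ncc1F` gives > 50000 nM, and this is a limit of the assay, not a number. The position of compound 2 is therefore known only as the limit of > 50000 nM in this assay, at which 1 of the 2 values shown sits.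

The next change leads to compound 3 `CS(=O)(=O)Nc1ccccc1Nc1nc(Nc2ccc(Oc3ccccc3)cc2)ncc1F`. It is phenoxy in place of benzyloxycarbonyl on an aromatic carbon, para to a large group. Within the data shown here, no step between measured compounds is available to size this change, so any expectation is loose.

The estimated step in this assay is an at least 1.6-fold lower number from compound 2 to compound 3 (0.22 log units; that floor lies within the scatter), expected to be small and in the direction of stronger inhibition of growth. This expectation rests on compound 1, whose 15500 nM shows that a compound with the shared core can return a number here. Another reading at the limit remains possible. Compound 3 is estimated at 30000 nM, with an expected range from 10000 nM to 60000 nM.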

Compound 3, concentration for 50% growth inhibition: 37400 nM
For compound 3 the middle estimate is 1.2-fold (0.10 log units) below the measured one, and the stated range covers the measured number.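

With phenoxy in place of benzyloxycarbonyl on an aromatic carbon, para to a large group, compound 3 returns a number in this assay, so this place on the ring can carry phenoxy and still give a reading rather than a limit. The change reads as an at least 1.3-fold lower number from compound 2 to compound 3 (0.12 log units; that floor lies within the scatter) and, as printed there, that floor does not separate the two compounds beyond the usual scatter of the measurement. Going by these compounds, the true size of the step stays unknown, since only a floor can be drawn from the reading of compound 2, which is a limit and not a number: the limit of > 50000 nM in this assay, at which 1 of the 3 values shown sits.

The compounds shown leave open whether the oxygen link, the carbonyl that leaves with benzyloxycarbonyl, or the outer aromatic ring carries any effect on growth inhibition at this place, and benzyloxy, benzoyl or a plain carboxylic acid there would begin to separate these parts. On these data alone, it is also open whether an amine or a longer chain on this aromatic carbon would move the reading clearly beyond the scatter, in either direction, from that of compound 3.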